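Fluoro in place of methoxy on compound 3

The source may hold more compounds than are shown below. What is called first, only, known or untested is meant among the compounds shown, and "the series" means these compounds.

The measured compounds in a functional assay on HeLa cells (Homo sapiens) for inhibition, read by sulforhodamine B assay (on this read-out higher numbers stand for weaker inhibition and lower numbers for stronger inhibition), are these
- compound 1 `O=C1C(Nc2ccc(C(F)(F)F)cc2)=CC(=O)c2c1nc1n2[C@H]2OC[C@@H](O)[C@H]2OC1` gives 8920 nM
- compound 2 `O=C1C(NC2CC2)=CC(=O)c2c1nc1n2[C@H]2OC[C@@H](O)[C@H]2OC1` gives > 16000 nM as a limit
- compound 3 `COc1cccc(NC2=CC(=O)c3c(nc4n3[C@H]3OC[C@@H](O)[C@H]3OC4)C2=O)c1` gives > 8000 nM as a limit

Compound 3 stands at > 8000 nM and this is a limit, not a number. Compound 2 with > 16000 nM is likewise held at a limit. Among the compounds with values here, compound 1 with 8920 nM is the only real number so far.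

Compound 4 `O=C1C(Nc2cccc(F)c2)=CC(=O)c2c1nc1n2[C@H]2OC[C@@H](O)[C@H]2OC1` differs from compound 3 in one group, and fluoro in place of methoxy on an aromatic carbon gives the count for that change, fluoro in place of methoxy on an aromatic carbon.

Of the measured steps, an at least 1.7-fold higher number from compound 1 to compound 2 (0.25 log units; that floor lies within the scatter) is the only one with a readable size. The other two, a step that the limit leaves unreadable from compound 1 to compound 3 and a step that the two limits leave unreadable from compound 2 to compound 3, give nothing to read. Within the data shown here, no measured step puts fluoro in place of methoxy, so the data give no direction, and no step beyond the scatter is expected. Among the measured compounds shown here, compound 1 with 8920 nM also carries a substituted phenyl on the amine nitrogen, and it is the one real number to lean on.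

The expected change is a step that the limit leaves unreadable from compound 3 to compound 4 and it is only an estimate. For compound 4 the estimated value is 10000 nM with an expected range from 4500 nM to 20000 nM and the result may again be only a limit.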

Compound 4, half-maximal inhibitory concentration: > 8000 nM
Compound 4: a limit, no number; the forecaster's own chance of this, stated with the estimate: 45%; the middle value is on the limit's open side.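

In this assay compound 4 gives > 8000 nM, which is a limit and not a number. The steps to compound 4 from compound 1, compound 2 and compound 3 therefore cannot be read. The compounds shown leave open whether fluoro in place of methoxy on an aromatic carbon changes inhibition at all, and what actual numbers compound 3 and compound 4 would give.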